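Switching the carbonyl substituent from aryl to arylamino

The source may report more compounds than this note shows. Statements on the series, on what has been measured and on what is new or still open speak of the compounds shown alone.

Among the compounds with values here, compound 1 `COc1cc(-c2nnc(SCC(=O)c3cccc(Br)c3)n2N)cc(OC)c1OC` is the only member of this set with an actual number in a functional assay on HepG2 cells (Homo sapiens) for antiproliferative activity, read by MTT assay, with a stated time of 48 h (a higher number here means a weaker inhibitor, a lower number a stronger inhibitor), where compound 1 gives 56000 nM. Compound 2 `COc1cc(-c2nnc(SCC(=O)Nc3ccccc3C)n2N)cc(OC)c1OC` carries a (2-methylphenyl)amino group on the carbonyl carbon; in this assay compound 2 reaches only the limit of the assay, > 100000 nM. Compound 3 `COc1cc(-c2nnc(SCC(=O)Nc3ccc(C)cc3)n2N)cc(OC)c1OC`, with a (4-methylphenyl)amino group in the same place, likewise shows only a limit in this assay, > 100000 nM. The step of an at least 1.7-fold higher number from compound 1 to compound 2 (0.25 log units; that floor lies within the scatter) and the step of an at least 1.7-fold higher number from compound 1 to compound 3 (0.25 log units; that floor lies within the scatter) therefore each carry a floor that lies within the usual scatter, and the step that the two limits leave unreadable from compound 2 to compound 3 cannot be read, since both ends sit at the limit of > 100000 nM in this assay, at which 2 of the 3 values shown sit.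

Compound 4 `COc1cccc(NC(=O)CSc2nnc(-c3cc(OC)c(OC)c(OC)c3)n2N)c1` differs from compound 1 by the change ((3-methoxyphenyl)amino in place of 3-bromophenyl on a carbonyl carbon). Both measured changes of the same kind, the 3-bromophenyl on the carbonyl carbon giving way to an arylamino group, pushed the reading of compounds 2 and 3 to the limit, so for compound 4 a weakening in this assay of at least that size is expected, with a substantial chance that only a limit is returned. Compound 4 is accordingly estimated at 120000 nM, within 50000 nM to 300000 nM. The expected step is a 2.1-fold higher number from compound 1 to compound 4 (0.33 log units; beyond the scatter).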

Compound 4, half-maximal inhibitory concentration: > 100000 nM
Compound 4: only a limit was reported; the forecaster's own chance of this, stated with the estimate: 65%; the middle value does not contradict the limit.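

Compound 4 extends the picture to a third arylamino group, and one that carries methoxy rather than methyl on its ring: the (3-methoxyphenyl)amino group on the carbonyl carbon also returns only a limit in this assay. The change gives an at least 1.7-fold higher number from compound 1 to compound 4 (0.25 log units; that floor lies within the scatter), so, as with the two earlier changes of this kind, no real weakening is established, although no arylamino compound shown gives an actual number. Swapping methyl for methoxy on the arylamino ring therefore brings no reading back into the measurable range, and the set now stands as follows: the limit of > 100000 nM in this assay, at which 3 of the 4 values shown sit.

Going by these compounds, the steps among compound 2, compound 3 and compound 4 cannot be read, so nothing separates these three arylamino groups, and how far each lies from compound 1 remains unknown. A (3-bromophenyl)amino group on the carbonyl carbon would keep the bromine of compound 1 while adding the amide nitrogen, and would show whether the nitrogen or the ring substituent governs the reading.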